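Series notes: compound 3 expected from compound 2

This account rests on a few compounds, and the source may have more. Where it says the series, first, only, none or still open, it means among the compounds named here.

Measured in a functional assay on A549 cells (Homo sapiens) for antiproliferative activity, read by MTT assay, with a stated time of 24 h; on this read-out lower numbers stand for stronger inhibition and higher numbers for weaker inhibition:
compound 1, `COc1ccc(-c2cc(/C=C/C(=O)c3ccc(C)c(C)c3)nc3cc(-c4ccccc4)nn23)cc1OC`, gives 9300 nM
compound 2, `COc1cc(-c2cc(/C=C/C(=O)c3ccccc3)nc3cc(-c4ccccc4)nn23)cc(OC)c1OC`, gives 18200 nM

Compound 2 has the higher of the two numbers, with compound 1 a nearer neighbour whose gap to it lies within the scatter; the two compounds differ in more than one place, so their values are noted without further reading. Compound 3, `COc1cc(-c2cc(/C=C/C(=O)c3ccc(C)c(C)c3)nc3cc(-c4ccccc4)nn23)cc(OC)c1OC`, is not yet measured. It differs from compound 2 by 3,4-dimethylphenyl in place of phenyl on a carbonyl carbon. Compound 1 carries the same 3,4-dimethylphenyl group, and its number sits close to that of compound 2, so no shift beyond the scatter is expected in this assay from this change alone. The step from compound 2 to compound 3 is estimated as a 1.5-fold lower number from compound 2 to compound 3 (0.18 log units; within the scatter). Compound 3 is expected to give about 12000 nM, within 5000 nM to 30000 nM.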

Compound 3, half-maximal inhibitory concentration: 10600 nM
Compound 3: middle estimate off by 1.1-fold (0.05 log units), on the high side; measured number inside the range.
By their numbers in this assay, from the lowest: compounds 1, 3 and 2 (each within the scatter of the next).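

In this assay, 3,4-dimethylphenyl in place of phenyl on a carbonyl carbon can now be read as a single change: a 1.7-fold lower number from compound 2 to compound 3 (0.23 log units; within the scatter). On this background, the added methyl groups give no step beyond the scatter. Among these compounds, with 3,4-dimethylphenyl held fixed, methoxy in place of hydrogen on an aromatic carbon can also be read for the first time, as a 1.1-fold higher number from compound 1 to compound 3 (0.06 log units; within the scatter), so compound 1 and compound 3 cannot be told apart here. No accompanying measurement bears on either step.

Every step shown lies within the scatter, so the compounds shown do not establish any change at either place that clearly shifts the number. Going by these compounds, it remains open whether an amine, a carboxylic acid or a longer chain in place of 3,4-dimethylphenyl on the carbonyl carbon would produce a step beyond the scatter.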